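Halogen-Rich Aryl Group on the Sulfonamide Nitrogen

This account rests on a few compounds, and the source may have more. Where it says the series, first, only, none or still open, it means among the compounds named here.

Compound 1 `COc1ccc(S(=O)(=O)Nc2cccc(Br)c2)cc1N1CCNCC1`: 1.26 nM in an assay on isolated protein for binding affinity to 5-hydroxytryptamine receptor 6 (Homo sapiens); on this read-out higher numbers stand for weaker inhibition and lower numbers for stronger inhibition
Compound 2 `COc1ccc(Cl)cc1NS(=O)(=O)c1ccc(OC)c(N2CCNCC2)c1`: 1.26 nM

Compound 1 stands level with compound 2 on this assay; the step from compound 1 to compound 2 is no change at the digits printed from compound 1 to compound 2 (within the scatter), so that exchange of the aryl group on the sulfonamide nitrogen left the inhibition constant unaltered. Compound 3 `COc1ccc(S(=O)(=O)Nc2cc(Br)cc(Cl)c2Br)cc1N1CCNCC1` has not yet been measured. It differs from compound 1 by 2,5-dibromo-3-chlorophenyl in place of 3-bromophenyl on a sulfonamide nitrogen. Among the compounds with values here, the only measured step that bears on this change is no change at the digits printed from compound 1 to compound 2 (within the scatter), which also swapped the aryl group on the same nitrogen and gave no change; the entering 2,5-dibromo-3-chlorophenyl group carries more halogens than either aryl group seen so far, so the evidence is thin. For compound 3 the expected step is a 1.3-fold higher number from compound 1 to compound 3 (0.10 log units; within the scatter), no more than the scatter. Compound 3 is therefore estimated at 1.6 nM, with a range from 0.5 nM to 5 nM.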

Compound 3, inhibition constant: 3.98 nM
Compound 3: the middle estimate sits 2.5-fold (0.40 log units) below what was measured, within the range that was stated.
By their numbers in this assay, from the lowest: compounds 1 and 2 (each within the scatter of the next); then compound 3.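

The aryl group on the sulfonamide nitrogen had until now been exchanged with no visible effect, but in this assay the 2,5-dibromo-3-chlorophenyl group gives a 3.2-fold higher number from compound 1 to compound 3 (0.50 log units; beyond the scatter) and likewise a 3.2-fold higher number from compound 2 to compound 3 (0.50 log units; beyond the scatter). This position is therefore not indifferent to every aryl group, although the shift seen here is modest and the same in size against both earlier compounds. Nothing available here accounts for the shift.

As far as these compounds go, it remains open which of the halogens in the 2,5-dibromo-3-chlorophenyl group, or how many of them, produce this step. Also open, from the compounds shown here alone, is how this sulfonamide nitrogen would respond to a phenyl group carrying an amine or a carboxylic acid, or to a saturated group such as cyclohexyl in place of the aryl ring.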